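Working notes on cytotoxicity for compounds 1 to 4

A few compounds are considered here, and "the series" means these few. Any claim that something is new, unique, unknown or untested is made for them only; others in the source may bear on it.

For the measured compounds named here, compound 1 `Oc1cccc(-c2cc(-c3ccc(Cl)cc3)nc(-c3ccsc3)c2)c1` is the only member with a number in an ADME assay on HEK293 cells (Homo sapiens) for cytotoxicity, read by CCK-8 assay and cell counting, with a stated time of 2 days; on this read-out higher numbers stand for weaker inhibition and lower numbers for stronger inhibition; compound 1 gives 11200 nM. Compound 2 `Oc1ccc(-c2cc(-c3ccncc3)nc(-c3ccc(Cl)cc3)c2)cc1` carries no result in this assay, as compound 2 gives "not determined" (no result reported). Compound 3 `Oc1cccc(-c2cc(-c3ccncc3)nc(-c3cccc(Cl)c3)c2)c1` likewise carries no result in this assay, as compound 3 gives "not determined" (no result reported); so compound 3 stands without a number, and one further member stands the same way. Compound 4 `Oc1cccc(-c2cc(-c3ccncc3)nc(-c3ccc(Cl)cc3)c2)c1` is the next member. Compound 4 differs from compound 3 as follows: 4-chlorophenyl in place of 3-chlorophenyl on an aromatic carbon. Going by the values given here, no measured pair shows this change, so nothing indicates whether it moves the read-out beyond the usual scatter in this assay; no shift in either direction beyond that scatter is assumed. Weak inhibition is all that is seen where a number exists, as compound 1 gives 11200 nM. Compound 4 is therefore expected to give 15000 nM, with an expected range from 4000 nM to 60000 nM.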

Compound 4, half-maximal inhibitory concentration: 2890 nM
Compound 4: middle estimate off by 5.2-fold (0.72 log units), on the high side; the whole stated range lies above it.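

Pyridin-4-yl in place of thiophen-3-yl on an aromatic carbon gives a 3.9-fold lower number from compound 1 to compound 4 (0.59 log units; beyond the scatter) in this assay, so this place on the shared core does move the read-out, modestly but beyond the usual scatter. The change from 3-chlorophenyl to 4-chlorophenyl cannot be read, as compound 3 has no number. Nothing on hand accounts for the step.

From the compounds shown here alone, whether an amine or a carboxylic acid at this place would shift the number further remains open. So does the effect of moving the chlorine on the phenyl ring.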